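The compounds below may be only part of what the source reports. "The series", "measured", "known", "first", "only" and "open" are said of these compounds alone.

For the measured compounds named here, compound 1 `CC1(C)N=C(N)N=C(N)N1c1ccccc1S` is the stronger of the two compounds measured so far in an assay for inhibition of Dihydrofolate reductase (Bos taurus), at pH 7.20; on this read-out lower numbers stand for lower potency and higher numbers for higher potency (the scale is a negative logarithm): compound 1 gives 7.69, the highest of the two numbers, while compound 2 `CC1(C)N=C(N)N=C(N)N1c1ccccc1F`, which carries fluoro in place of sulfanyl on an aromatic carbon, gives 5.41. Going by the values given here, that single step, a number 2.28 log units lower from compound 1 to compound 2 (beyond the scatter), is the only comparison available, and it is a large one.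

Compound 3 `CCc1ccccc1N1C(N)=NC(N)=NC1(C)C` has not yet been measured. It differs from compound 1 as follows: ethyl in place of sulfanyl on an aromatic carbon. The entering ethyl, like the fluoro of compound 2, brings no hydrogen-bond donor and no hydrogen-bond acceptor, whereas the sulfanyl that leaves counted one of each. On the evidence of a number 2.28 log units lower from compound 1 to compound 2 (beyond the scatter), replacing the sulfanyl on this aromatic carbon is expected to cost potency in this assay, though with a group of two carbons rather than fluoro the drop is expected to be smaller than the measured one. Compound 3 is therefore estimated at 6.3, within a range of 5.4 to 7.3, a step of a number 1.39 log units lower from compound 1 to compound 3 (beyond the scatter).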

Compound 3, logarithm of the reciprocal of the active concentration, log(1/C): 4.48
The estimate for compound 3 lay 1.82 log units above the measured number; the whole stated range lies above it.
By their numbers in this assay, from the lowest: compound 3; then compound 2; then compound 1.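

Ethyl does not merely repeat the loss seen with fluoro: in this assay the change at this position is a number 3.21 log units lower from compound 1 to compound 3 (beyond the scatter), which goes further than a number 2.28 log units lower from compound 1 to compound 2 (beyond the scatter). The two replacements of sulfanyl are also not interchangeable, since the step between them is a number 0.93 log units lower from compound 2 to compound 3 (beyond the scatter), so the ethyl and fluoro groups are told apart at this place even though neither brings a hydrogen-bond donor or acceptor. Among these three compounds sulfanyl gives the highest number, but nothing presented here accounts for that order or for the gap between fluoro and ethyl.

The compounds shown leave open whether a hydroxyl or an amine on this aromatic carbon, each of which would also replace sulfanyl with a group other than fluoro or ethyl, could hold the number near that of compound 1. They also leave open how methyl or a longer chain such as propyl would compare with ethyl, and so whether the number keeps moving as the carbon chain changes.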